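Cytotoxicity notes on a biaryl amide series

The source may report more compounds than this note shows. Statements on the series, on what has been measured and on what is new or still open speak of the compounds shown alone.

Measured so far:
compound 1 `CC(C)N(Cc1cccc(OCCCCCC(=O)O)c1)C(=O)c1ccc(-c2cc3ccccc3n2S(=O)(=O)c2ccccc2)cc1`: > 26000 nM
compound 2 `COc1ccc(F)c(-c2ccc(C(=O)N(Cc3cccc(OCCCCCC(=O)O)c3)C(C)C)cc2)c1`: > 26000 nM
compound 3 `CCOC(=O)CCCCCOc1cccc(CN(C(=O)c2ccc(-c3cccc(Oc4ccccc4)c3)cc2)C(C)C)c1`: > 19600 nM

In an ADME assay on Raji cells (Homo sapiens) for cytotoxicity, read by CellTiter-Glo and resazurin assay, with a stated time of 72 h (on this read-out lower numbers stand for an effect already at smaller amounts and higher numbers for an effect only at larger amounts of compound), compound 1 gives > 26000 nM, which is a limit of the assay and not a number. Compound 2 gives > 26000 nM in this assay, again a limit. Compound 3 gives > 19600 nM in this assay, also a limit. Compound 3 thus stands at the limit of > 19600 nM in this assay, at which 1 of the 3 values shown sits. The two remaining values sit at the limit of > 26000 nM in this assay, at which 2 of the 3 values shown sit. Within the data shown here, none of the three values is a number, so no step between measured compounds can be stated, and the three cannot be ordered among themselves.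

Compound 4 `CCOC(=O)CCCCCOc1cccc(CN(C(=O)c2ccc(-c3cccc(S(C)(=O)=O)c3)cc2)C(C)C)c1` is not yet measured in this assay. It differs from compound 3 in one place: methylsulfonyl in place of phenoxy on an aromatic carbon. With every measured value a limit, no direction can be drawn from the series; the expectation is no change beyond the scatter, with compound 4 most likely returned as a limit as well. The step that the limit leaves unreadable from compound 3 to compound 4 is what is expected. Compound 4 is expected to give about 30000 nM in this assay, with a range from 15000 nM to 60000 nM.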

Compound 4, half-maximal effective concentration: > 26000 nM
Compound 4 gave a limit, no number; the forecaster's own chance of this, stated with the estimate: 85%; the middle value is on the limit's open side.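

In this assay, among these compounds, compound 3 and compound 4 both return limits and no number, so no step between them can be read. The compounds shown leave open at what concentration, if any, either the phenoxy or the methylsulfonyl compound would produce an effect on these cells.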